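Biphenyl amide series: benzyl to phenyl on the amide nitrogen

The source may report more compounds than this note shows. Statements on the series, on what has been measured and on what is new or still open speak of the compounds shown alone.

Of the compounds shown here, three have been measured in an in vitro functional assay on HEK ts201 cells for antagonist activity at Neuronal acetylcholine receptor; alpha3/beta4 (Homo sapiens), read by fluorescence and calcium flux; a higher number here means a weaker inhibitor, a lower number a stronger inhibitor. Compound 1 `O=C(OCc1ccccc1-c1ccccc1)C1CCCN(CCCc2ccccc2)C1` gives 10200 nM, compound 2 `O=C(NCc1ccccc1)c1ccccc1-c1ccccc1` gives 7600 nM, and compound 3 `O=C(OCC1=CCCN(CCCc2ccccc2)C1)c1ccccc1N1C(=O)CC(Cc2ccccc2)C1=O` gives 3720 nM. Compound 2 stands second highest of the three numbers; its nearest neighbour is compound 1, within the scatter, and its furthest is compound 3, whose lower number lies beyond the scatter. Among the measured compounds shown here, no two measured compounds differ in a single place, so no step is on record. Compound 4 `O=C(Nc1ccccc1)c1ccccc1-c1ccccc1` differs from compound 2 by phenyl in place of benzyl on an amide-type nitrogen. For the measured compounds named here, with no comparable step among the measured compounds, the expected step is a 1.1-fold higher number from compound 2 to compound 4 (0.02 log units; within the scatter), not beyond the scatter in either direction. Compound 4 is estimated at 8000 nM, with a range from 3000 nM to 25000 nM.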

Compound 4, half-maximal inhibitory concentration: 10700 nM
Compound 4: middle estimate off by 1.3-fold (0.13 log units), on the low side; measured number inside the range.
By their numbers in this assay, from the lowest: compound 3; then compounds 2, 1 and 4 (each within the scatter of the next).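

In this assay, among the compounds shown here, the first single-place step reads a 1.4-fold higher number from compound 2 to compound 4 (0.15 log units; within the scatter) and so gives a first reading at the amide-type nitrogen. At this position, phenyl and benzyl cannot be told apart, so this change alone leaves the number within the scatter. No measured evidence bears on this result.

On these data alone, it remains open whether a longer chain such as phenethyl on this nitrogen would give a step beyond the scatter. An amine or a carboxylic acid on the aromatic ring of this substituent is equally unresolved.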